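The source may hold more compounds than are shown below. What is called first, only, known or untested is meant among the compounds shown, and "the series" means these compounds.

Measured compounds:
compound 1 `Fc1ccc(/C=N/c2sc3c(c2-c2nc4ccccc4s2)CCC3)cc1`; in an ADME assay on HepG2 cells (Homo sapiens) for cytotoxicity, read by MTT assay, with a stated time of 72 h (on this read-out higher numbers stand for lower toxicity in this test and lower numbers for higher toxicity in this test), compound 1 gives 302 ug/mL.
compound 2 `Clc1ccc(/C=N/c2sc3c(c2-c2nc4ccccc4s2)CCC3)cc1`; compound 2 gives 431 ug/mL.
compound 3 `Clc1ccccc1/C=N/c1sc2c(c1-c1nc3ccccc3s1)CCC2`; compound 3 gives 180 ug/mL.

Compound 3 holds the lowest of the three numbers: against compound 1 the gap is a 1.7-fold lower number from compound 1 to compound 3 (0.22 log units; within the scatter), against compound 2 it is a 2.4-fold lower number from compound 2 to compound 3 (0.38 log units; beyond the scatter). Going by the values given here, the one change that keeps the substituent where it is reads a 1.4-fold higher number from compound 1 to compound 2 (0.15 log units; within the scatter).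

Compound 4 `Oc1ccccc1/C=N/c1sc2c(c1-c1nc3ccccc3s1)CCC2` is not yet measured. It differs from compound 3 by hydroxy in place of chloro on an aromatic carbon. Among the compounds with values here, no measured step exchanges a halogen for a hydroxy, so the precedent is indirect: the halogen exchange between compound 1 and compound 2 stayed within the scatter, and the two changes of where the substituent sits gave at most a modest shift. The step from compound 3 to compound 4 in this assay is therefore expected to be small, a 1.2-fold higher number from compound 3 to compound 4 (0.07 log units; within the scatter), with no firm direction. Compound 4 is expected to give about 210 ug/mL, in the range 100 ug/mL to 430 ug/mL.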

Compound 4, half-maximal cytotoxic concentration: 156 ug/mL
Estimate against measurement, compound 4: 1.3-fold (0.13 log units) above; low and high end bracket the measured number.
By their numbers in this assay, from the lowest: compounds 4, 3, 1 and 2 (each within the scatter of the next, the first and the last beyond it).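

On the aromatic carbon ortho to a large group, chloro and hydroxy are not told apart in this assay: a 1.2-fold lower number from compound 3 to compound 4 (0.06 log units; within the scatter). The split seen for the 2-chlorophenyl compound recurs with a second substituent at this place, as a 2.8-fold lower number from compound 2 to compound 4 (0.44 log units; beyond the scatter), whereas a 1.9-fold lower number from compound 1 to compound 4 (0.29 log units; within the scatter); the gap to the 4-chlorophenyl compound is thus not unique to chloro. Nothing available bears on the reason for these numbers.

The compounds shown leave open how an amine or a carboxylic acid would read on this carbon, and whether hydroxy elsewhere on the ring would stay close to the 2-hydroxyphenyl number. All four compounds share one core, so these readings apply to that core alone.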